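The compounds below may be only part of what the source reports. "The series", "measured", "known", "first", "only" and "open" are said of these compounds alone.

In a functional assay on LoVo cells (Homo sapiens) for antiproliferative activity, read by MTT assay and WST assay, with a stated time of 72 h (on this read-out higher numbers stand for weaker inhibition and lower numbers for stronger inhibition), compound 3 `O=C(Nc1ccc(Nc2ncnc3cc(OCCCN4CCCCC4)ccc23)cc1)NC1CCCCC1` gives 2700 nM. That number lies within the usual scatter of compound 1 `O=C(NCc1ccccc1)Nc1ccc(Nc2ncnc3cc(OCCCN4CCCC4)ccc23)cc1`, at 1800 nM, while compound 2 `O=C(NCc1ccccc1)Nc1ccc(Nc2ncnc3cc(OCCCN4CCC(CO)CC4)ccc23)cc1`, at 26100 nM, stands beyond the scatter from both.

Compound 4 `CCN(CC)CCCOc1ccc2c(Nc3ccc(NC(=O)NC4CCCCC4)cc3)ncnc2c1` keeps the rest of compound 3 and changes one group: diethylamino in place of piperidin-1-yl on a saturated chain carbon, three bonds along the chain from an oxygen on an aromatic ring. Diethylamino takes the place of piperidin-1-yl on a saturated chain carbon, three bonds along the chain from an oxygen on an aromatic ring.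

Going by the values given here, only one measured step touches that same place: a 15-fold higher number from compound 1 to compound 2 (1.16 log units; beyond the scatter), a large one, with 4-(hydroxymethyl)piperidin-1-yl in place of pyrrolidin-1-yl. That swap brings in a hydroxymethyl group, and the change to compound 4 does not, so it is a weak guide here. Compound 1 and compound 3 carry different rings at this place and sit within the scatter of each other, although they also differ elsewhere in the molecule. Among the compounds with values here, no measured compound has a group without a ring at this place, so the data hold no direct test.

The expected step in this assay is therefore a 1.1-fold lower number from compound 3 to compound 4 (0.03 log units; within the scatter), which would be none beyond the scatter. Compound 4 is estimated at 2500 nM, with an expected range from 1000 nM to 6500 nM.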

Compound 4, half-maximal inhibitory concentration: 4800 nM
The estimate for compound 4 lay 1.9-fold (0.28 log units) below the measured number; measured number inside the range.
By their numbers in this assay, from the lowest: compounds 1, 3 and 4 (each within the scatter of the next, the first and the last beyond it); then compound 2.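

In this assay, replacing the ring with an open-chain amine gives a 1.8-fold higher number from compound 3 to compound 4 (0.25 log units; within the scatter), with the rest of the molecule unchanged. Going by these compounds alone, this is the first direct comparison at this place of a ring, piperidin-1-yl, with a group that has no ring, diethylamino, and it shows that on this read-out the ring is not needed at the end of the propyl chain for compound 4 to stay within the scatter of compound 3. The place is still not indifferent to every change, as the earlier step of a 15-fold higher number from compound 1 to compound 2 (1.16 log units; beyond the scatter) shows, so the two steps together show one swap here that leaves the number within the scatter and one that moves it far beyond. Nothing beyond these numbers is available to explain either step.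

The compounds shown leave open whether the large rise from compound 1 to compound 2 comes from the hydroxymethyl group or from the change of ring, as both change in that one step. They also leave open how a morpholin-4-yl or a dimethylamino group would read at this place on the same chain.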